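Swapping a fluoro for an ethyl on the anilino ring

The source may report more compounds than this note shows. Statements on the series, on what has been measured and on what is new or still open speak of the compounds shown alone.

Three compounds sharing one core were tested in a functional assay on NCI-H1975 cells (Homo sapiens) for inhibition, read by MTT assay, with a stated time of 72 h; a lower number here means a stronger inhibitor, a higher number a weaker inhibitor. Compound 3 `C=CC(=O)Nc1cccc(NC(=O)CSc2nc(Nc3ccc(F)cc3)c3ccccc3n2)c1` gives 4430 nM, the lowest of the three numbers, while compound 1 `C=CC(=O)Nc1cccc(NC(=O)CSc2nc(Nc3ccccc3F)c3ccccc3n2)c1` gives 6580 nM and compound 2 `C=CC(=O)Nc1cccc(NC(=O)CSc2nc(Nc3ccccc3C)c3ccccc3n2)c1` gives 9920 nM. The gap a 1.5-fold lower number from compound 1 to compound 3 (0.17 log units; within the scatter) lies within the scatter, and a 2.2-fold lower number from compound 2 to compound 3 (0.35 log units; beyond the scatter) is only modest. Compound 4 `C=CC(=O)Nc1cccc(NC(=O)CSc2nc(Nc3ccc(CC)cc3)c3ccccc3n2)c1` differs from compound 3 by ethyl in place of fluoro on an aromatic carbon. Going by the values given here, no measured pair makes this exact exchange; the nearest is a 1.5-fold higher number from compound 1 to compound 2 (0.18 log units; within the scatter), a fluoro-to-methyl swap elsewhere, which stayed within the scatter. Compound 4 is therefore expected to stay close to compound 3, with a 1.2-fold higher number from compound 3 to compound 4 (0.09 log units; within the scatter). Compound 4 is estimated at 5500 nM, with a range from 2500 nM to 12000 nM.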

Compound 4, half-maximal inhibitory concentration: 8270 nM
For compound 4 the middle estimate is 1.5-fold (0.18 log units) below the measured one; measured number inside the range.
By their numbers in this assay, from the lowest: compounds 3, 1, 4 and 2 (each within the scatter of the next, the first and the last beyond it).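

On this aromatic carbon, ethyl replaces fluoro with a 1.9-fold higher number from compound 3 to compound 4 (0.27 log units; within the scatter), so in this assay the larger group leaves the number close to that of compound 3. The other two steps, a 1.2-fold lower number from compound 2 to compound 4 (0.08 log units; within the scatter) and a 1.3-fold higher number from compound 1 to compound 4 (0.10 log units; within the scatter), show that compound 4 cannot be told apart from any of the other three, even though compound 2 and compound 3 can be separated. No evidence is available to explain these numbers. Open, going by these compounds, is how an amine, a carboxylic acid or a longer chain on this carbon would compare with fluoro and ethyl.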